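The compounds below may be only part of what the source reports. "The series", "measured", "known", "first", "only" and "open" are said of these compounds alone.

Working notes on the series. Compound 1 `Cc1ncnc2c1c(-c1ccoc1)cn2[C@@H]1O[C@H](CO)[C@@H](O)[C@H]1O` carries a methyl on the shared core, and in a functional assay on HL-60 cells (Homo sapiens) for antiproliferative activity, read by XTT assay, with a stated time of 72 h (a lower number here means a stronger inhibitor, a higher number a weaker inhibitor), compound 1 gives > 15000 nM, a limit of the assay rather than a number. Compound 2 `CNc1ncnc2c1c(I)cn2[C@@H]1O[C@H](CO)[C@@H](O)[C@H]1O` bears an iodo group; in this assay compound 2 gives > 20000 nM, again a limit. Compound 3 `CNc1ncnc2c1c(-c1ccccc1)cn2[C@@H]1O[C@H](CO)[C@@H](O)[C@H]1O` has phenyl in place of iodo on an aromatic carbon. In this assay compound 3 gives > 20000 nM, also a limit. The step that the two limits leave unreadable from compound 2 to compound 3 is thus not readable, since both ends sit at limits (the limit of > 15000 nM in this assay, at which 1 of the 3 values shown sits; (the limit of > 20000 nM in this assay, at which 2 of the 3 values shown sit)). Compound 3 therefore stands at a limit, as do the other two values shown, and no ordering among the three can be drawn.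

Compound 4 `CNc1ncnc2c1c(-c1ccoc1)cn2[C@@H]1O[C@H](CO)[C@@H](O)[C@H]1O` differs from compound 3 by furan-3-yl in place of phenyl on an aromatic carbon. Within the data shown here, the only measured step touching this position, a step that the two limits leave unreadable from compound 2 to compound 3, is unreadable, so no size of step can be taken from it. Compound 1, which also carries the furan-3-yl group, gives only a limit. The expected step that the limit leaves unreadable from compound 3 to compound 4 is accordingly none beyond the scatter, with compound 4 expected to remain at or near the limit. Compound 4 is estimated at 25000 nM, within 8000 nM to 100000 nM.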

Compound 4, half-maximal inhibitory concentration: > 15000 nM
Compound 4 ended at the assay's limit; the forecaster's own chance of this, stated with the estimate: 80%; the middle value lies beyond the limit too.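

In this assay compound 4 gives > 15000 nM, a limit of the assay and not a number. The steps to compound 4 from compound 1, compound 2 and compound 3 cannot be read, since all four values are limits. The compounds shown leave open whether furan-3-yl, phenyl or iodo, or methylamino against methyl, changes activity at all.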